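The source may hold more compounds than are shown below. What is called first, only, known or untested is meant among the compounds shown, and "the series" means these compounds.

Series notes. Compound 1 `CC(C)C[C@H](NC(=O)OCC1CCC(F)(F)CC1)C(=O)N[C@@H](C[C@@H]1CCNC1=O)C(O)S(=O)(=O)O` carries the hydroxy(sulfo)methyl group; in an ADME assay on HEK-293T cells (Homo sapiens) for cytotoxicity, with a stated time of 72 h (on this read-out lower numbers stand for higher toxicity in this test and higher numbers for lower toxicity in this test), compound 1 gives "not determined" (no result reported); "not determined" (no result reported) (2 entries). Compound 2 `CC(C)C[C@H](NC(=O)OC(c1ccccc1)C1CCC(F)(F)CC1)C(=O)N[C@H](C=O)C[C@@H]1CCNC1=O` carries the formyl group instead. In this assay compound 2 gives > 100000 nM, which is a limit of the test and not a number. Compound 2 thus sits at the limit of > 100000 nM in this assay, at which 1 of the 2 values shown sits. Compound 3 `CC(C)C[C@H](NC(=O)OC(c1ccccc1)C1CCC(F)(F)CC1)C(=O)N[C@@H](C[C@@H]1CCNC1=O)C(O)S(=O)(=O)O` differs from compound 2 by hydroxy(sulfo)methyl in place of formyl on a saturated chain carbon bound to an amide-type nitrogen and a saturated chain carbon. Going by the values given here, no step between measured compounds is available, so for compound 3 no shift beyond the scatter is expected, a step of about a number no higher from compound 2 to compound 3 (the limit leaves the size open). For compound 3 the expected value in this assay is estimated at 100000 nM, with an expected range from 50000 nM to 200000 nM, most likely reported again as a limit.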

Compound 3, half-maximal cytotoxic concentration: > 100000 nM
Compound 3: a limit, no number (the forecaster's own chance of this, stated with the estimate: 85%); the middle value sits exactly at the limit.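

Going by these compounds alone, compound 2 and compound 3 both stop at a limit in this assay, so no step between them can be read. From the compounds shown here alone, whether hydroxy(sulfo)methyl in place of formyl changes the read-out stays open.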